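A few compounds are considered here, and "the series" means these few. Any claim that something is new, unique, unknown or untested is made for them only; others in the source may bear on it.

Of the compounds shown here, three of a shared core have been measured in a functional assay on A549 cells (Homo sapiens) for cytotoxicity, read by MTT assay, with a stated time of 72 h; on this read-out lower numbers stand for stronger inhibition and higher numbers for weaker inhibition. Compound 1 `CCOC(=O)c1sc2cccc(C)c2c1Nc1cc(OC)c(OC)c(OC)c1` gives 6250 nM in this assay, compound 2 `COC(=O)c1sc2cc(OC)ccc2c1Nc1cc(OC)c(OC)c(OC)c1` gives 8.5 nM, and compound 3 `CCOC(=O)c1sc2c(OC)c(C)c(C)c(C)c2c1Nc1cc(OC)c(OC)c(OC)c1` gives 33 nM. Compound 2 thus stands lowest of the three numbers, and its distance to both compound 3 and compound 1 lies beyond the usual scatter, so it is the most potent compound measured here. For the measured compounds named here, compounds 1 and 3 each differ from compound 2 in more than one place, so no single-point step between measured compounds is available.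

Compound 4 `COC(=O)c1sc2cc(C)ccc2c1Nc1cc(OC)c(OC)c(OC)c1` has not yet been measured. It differs from compound 2 in one place: methyl in place of methoxy on an aromatic carbon. Without a measured single-point step of this kind, the size of the change can only be estimated, and compound 4 is expected to fall close to compound 2, with a step of a 2.9-fold higher number from compound 2 to compound 4 (0.47 log units; beyond the scatter) of small size toward a higher number, near or just beyond the scatter. Compound 4 is therefore estimated at 25 nM in this assay, with a range from 6 nM to 100 nM.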

Compound 4, half-maximal inhibitory concentration: 10.8 nM
For compound 4 the middle estimate is 2.3-fold (0.36 log units) above the measured one; measured number inside the range.
By their numbers in this assay, from the lowest: compounds 2 and 4 (each within the scatter of the next); then compound 3; then compound 1.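

In this assay, the only single-place step shown puts methyl in place of methoxy on an aromatic carbon meta to a fused ring and para to a fused ring, and a 1.3-fold higher number from compound 2 to compound 4 (0.10 log units; within the scatter) stays within the scatter. At this position, the methoxy oxygen and its one hydrogen-bond acceptor can therefore be lost with no change beyond the scatter, which compound 1 and compound 3 could not show, as each differs from compound 2 in more than one place. Nothing given here explains why the two groups read alike.

The compounds shown leave open how an amine, a hydroxyl or a longer chain such as ethoxy would read at this position. They also leave open whether the same step would read alike on an ethyl ester.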